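The compounds below may be only part of what the source reports. "The series", "measured", "known", "first", "only" and "open" are said of these compounds alone.

Working notes on the series.

Of the compounds shown here, two of the shared core have been measured. Compound 1 `COc1cc(-c2cc(/C=C/C(=O)c3ccc(N)cc3)[nH]n2)cc(OC)c1OC` carries a 4-aminophenyl on the carbonyl carbon and, in a functional assay on UACC-257 cells (Homo sapiens) for inhibition, read by sulforhodamine B assay, with a stated time of 48 h (a higher number here means a weaker inhibitor of growth, a lower number a stronger inhibitor of growth), compound 1 gives 1870 nM. Compound 2 `COc1ccc(-c2cc(/C=C/C(=O)c3ccc(OC)c(OC)c3)[nH]n2)cc1` differs at both aryl ends and, in this assay, compound 2 gives 1730 nM. On these two numbers compound 1 and compound 2 sit together: the gap between them is smaller than the usual scatter of this kind of measurement, so neither can be called the stronger inhibitor of growth.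

Compound 3 `COc1cc(-c2cc(/C=C/C(=O)c3ccc(Cl)c(Cl)c3)[nH]n2)cc(OC)c1OC` is the next member and has not yet been measured in this assay. Relative to compound 1 the change is 3,4-dichlorophenyl in place of 4-aminophenyl on a carbonyl carbon. Among the measured compounds shown here, no measured pair isolates a change at this position, so there is nothing to anchor the size of the step. For the measured compounds named here, the two numbers so far suggest that changes at the aryl ends leave the growth inhibition close to where it was, and the step of a 1.3-fold higher number from compound 1 to compound 3 (0.13 log units; within the scatter) is therefore expected to stay within the scatter, with a slight lean towards a weaker inhibitor. For compound 3 the value in this assay is estimated at 2500 nM, with a range from 800 nM to 8000 nM.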

Compound 3, concentration for 50% growth inhibition: 16300 nM
For compound 3 the middle estimate is 6.5-fold (0.81 log units) below the measured one; the measured number lies above the stated range.
By their numbers in this assay, from the lowest: compounds 2 and 1 (each within the scatter of the next); then compound 3.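

In this assay, 3,4-dichlorophenyl in place of 4-aminophenyl on a carbonyl carbon gives an 8.7-fold higher number from compound 1 to compound 3 (0.94 log units; beyond the scatter), the first step in the compounds shown that lies beyond the scatter, so growth inhibition in this series is sensitive to the group at this position. Among the compounds shown here, the change replaces a group with 1 hydrogen-bond donor and 1 hydrogen-bond acceptor by one with 0 hydrogen-bond donors and 0 hydrogen-bond acceptors, but this single pair records only that the two groups differ in the assay and does not assign the step to any one feature of either group. No measurement is available that accounts for the size of this step.

The compounds shown leave open whether the step follows the loss of the amino group or the entry of the chlorine atoms, a question that a plain phenyl or a 4-chlorophenyl on the same carbonyl carbon would help to separate. Also open, on these data alone, is whether another nitrogen-bearing group, such as 4-(dimethylamino)phenyl, would stay close to compound 1 at 1870 nM or move towards the weaker end.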